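A few compounds are considered here, and "the series" means these few. Any claim that something is new, unique, unknown or untested is made for them only; others in the source may bear on it.

Measured so far in a functional assay on A549 cells (Homo sapiens) for cytotoxicity, read by MTT assay, with a stated time of 72 h; a lower number here means a stronger inhibitor, a higher number a weaker inhibitor:
compound 1 `[O-][n+]1nc(NCOCc2ccc(Cl)cc2)[n+]([O-])c2ccccc21` gives 1470 nM
compound 2 `COCNc1n[n+]([O-])c2ccccc2[n+]1[O-]` gives 7450 nM
compound 3 `CC(C)CCOCNc1n[n+]([O-])c2ccccc2[n+]1[O-]` gives 7270 nM

Compound 3 sits level with compound 2, within the scatter of each other, while compound 1 shows the lowest number of the three. Compound 4 `CCCCCOCNc1n[n+]([O-])c2ccccc2[n+]1[O-]` has the same atoms as compound 3, joined differently: propyl in place of isopropyl on a saturated chain carbon, two bonds along the chain from an oxygen on a saturated carbon with propyl in place of isopropyl on a saturated chain carbon, two bonds along the chain from an oxygen on a saturated carbon. Going by the values given here, two steps bear on this. Isobutyl in place of hydrogen gave a 1.0-fold lower number from compound 2 to compound 3 (0.01 log units; within the scatter) and that swap changed more than this one does. Isobutyl in place of 4-chlorophenyl gave a 4.9-fold higher number from compound 1 to compound 3 (0.69 log units; beyond the scatter) but that swap removed a ring, which does not happen here. No step beyond the scatter is therefore expected in this assay for this change. The expected result is a 1.0-fold lower number from compound 3 to compound 4 (0.02 log units; within the scatter) according to this estimate. For compound 4 the estimated value is 7000 nM with an expected range of 3800 nM to 12000 nM in this test.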

Compound 4, half-maximal inhibitory concentration: 6460 nM
Estimate against measurement, compound 4: 1.1-fold (0.03 log units) above; measured number inside the range.
By their numbers in this assay, from the lowest: compound 1; then compounds 4, 3 and 2 (each within the scatter of the next).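

In this assay, isopentyl to pentyl gives a 1.1-fold lower number from compound 3 to compound 4 (0.05 log units; within the scatter) and so shows that, at this place, the branch makes no readable difference. Butyl in place of hydrogen gives a 1.2-fold lower number from compound 2 to compound 4 (0.06 log units; within the scatter) while butyl in place of 4-chlorophenyl gives a 4.4-fold higher number from compound 1 to compound 4 (0.64 log units; beyond the scatter) and so the straight chain, like the branched one, stays level with hydrogen and apart from 4-chlorophenyl. Nothing available gives a reason for these results. Still open, on these data alone, is whether a longer chain or a terminal amine would stay level with these chains. Also open, as far as these compounds go, is whether plain phenyl would match compound 1.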